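A few compounds are considered here, and "the series" means these few. Any claim that something is new, unique, unknown or untested is made for them only; others in the source may bear on it.

Compound 1 `Cc1ccc(NC2=CC(=O)c3nc4n(c3C2=O)[C@H]2OC[C@@H](O)[C@H]2OC4)cc1` gives 3860 nM in a functional assay on HeLa cells (Homo sapiens) for inhibition, read by sulforhodamine B assay; on this read-out lower numbers stand for stronger inhibition and higher numbers for weaker inhibition.
Compound 2 `O=C1C=C(NCc2ccccc2)C(=O)c2c1nc1n2[C@H]2OC[C@@H](O)[C@H]2OC1` reached only a limit of the assay, > 8000 nM in this assay.
Compound 3 `COc1cccc(NC2=CC(=O)c3nc4n(c3C2=O)[C@H]2OC[C@@H](O)[C@H]2OC4)c1` gives 4280 nM in this assay.

Among the two numbers obtained, compound 3 has the higher one, though its nearest neighbour is compound 1, separated by a 1.1-fold higher number from compound 1 to compound 3 (0.04 log units; within the scatter), so the two cannot be told apart. Compound 4 `CCc1ccc(NC2=CC(=O)c3nc4n(c3C2=O)[C@H]2OC[C@@H](O)[C@H]2OC4)cc1` differs from compound 3 in one place: 4-ethylphenyl in place of 3-methoxyphenyl on an amine nitrogen.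

Two measured steps speak to an exchange of one aromatic substituent for another on this amine nitrogen. The closest is the swap from compound 1 to compound 3, a 1.1-fold higher number from compound 1 to compound 3 (0.04 log units; within the scatter), which shows that two differently substituted phenyl groups on the shared core gave the same result. The steps of an at least 2.0-fold higher number from compound 1 to compound 2 (0.31 log units; beyond the scatter) and an at least 1.8-fold lower number from compound 2 to compound 3 (0.27 log units; that floor lies within the scatter) involve benzyl and are bounded by the limit (the limit of > 8000 nM in this assay, at which 1 of the 3 values shown sits), so they say little about a phenyl-to-phenyl change. Compound 4 keeps a phenyl ring and is therefore expected to show no step beyond the scatter; the expected move is a 1.1-fold lower number from compound 3 to compound 4 (0.04 log units; within the scatter). Compound 4 is estimated to give 3900 nM, with a range from 1800 nM to 8000 nM.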

Compound 4, half-maximal inhibitory concentration: 3990 nM
The estimate for compound 4 lay 1.0-fold (0.01 log units) below the measured number; the measured number falls inside the stated range.
By their numbers in this assay, from the lowest: compounds 1, 4 and 3 (each within the scatter of the next). At a limit, above all of these: compound 2.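

In this assay the exchange of 3-methoxyphenyl for 4-ethylphenyl gave a 1.1-fold lower number from compound 3 to compound 4 (0.03 log units; within the scatter) and so removed the one hydrogen-bond acceptor of this group with no change beyond the scatter, which means that among compounds 1, 3 and 4 the oxygen of the methoxy group is not required for this level of inhibition. Adding a single carbon to the chain on the ring gave a 1.0-fold higher number from compound 1 to compound 4 (0.01 log units; within the scatter) and so showed that 4-methylphenyl and 4-ethylphenyl on this amine nitrogen cannot be told apart. The step of an at least 2.0-fold lower number from compound 2 to compound 4 (0.30 log units; that floor lies within the scatter) cannot be read as a true size because it rests on the limit for compound 2: the limit of > 8000 nM in this assay, at which 1 of the 4 values shown sits.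

The compounds shown leave open whether a phenyl ring carrying a carboxylic acid, an amine or a much longer chain such as hexyl would move the number beyond the scatter in either direction. They also leave open whether a saturated ring such as cyclohexyl on this nitrogen would match the phenyl groups of compounds 1, 3 and 4.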